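A Carboxylic Acid Enters at the Aryl Ether End

The source may hold more compounds than are shown below. What is called first, only, known or untested is meant among the compounds shown, and "the series" means these compounds.

In an assay on HEK293 cells for positive allosteric modulation of metabotropic glutamate receptor 2 (Rattus norvegicus), read by thallium flux, with a stated time of 2.5 min (on this read-out lower numbers stand for smaller maximal responses and higher numbers for larger maximal responses), compound 1 `COC(=O)c1ccc(OCCCCOc2ccc(C(=O)CC3CCCC3)c(O)c2C)cc1` gives 12.2%, compound 2 `COC(=O)c1ccc(OCCCCOc2ccc(C(=O)CC(C)C)c(O)c2C)cc1` gives 16.4%, and compound 3 `Cc1cc(C(=O)O)ccc1OCCCCOc1ccc(C(=O)CC2CCCC2)c(O)c1C` gives 84.6%. Compound 2 stands second highest of the three numbers: compound 1 lies within the scatter of it, compound 3 well above. Compound 4 `Cc1c(OCCCCOc2ccc(F)c(C(=O)O)c2)ccc(C(=O)CC(C)C)c1O` differs from compound 2 in one place: 3-carboxy-4-fluorophenyl in place of 4-(methoxycarbonyl)phenyl on an oxygen on a saturated carbon. Within the data shown here, two measured steps bear on this. Among the measured compounds shown here, the step of a number 4.2 percentage points higher from compound 1 to compound 2 (within the scatter) stays within the scatter, whereas a number 72.4 percentage points higher from compound 1 to compound 3 (beyond the scatter) brought a large gain when 4-carboxy-2-methylphenyl replaced 4-(methoxycarbonyl)phenyl, a change that, like the one to compound 4, brings in a carboxy group. Because compound 3 reaches 84.6%, compound 4 is expected to rise too, by about a number 48.6 percentage points higher from compound 2 to compound 4 (beyond the scatter) in this assay. Compound 4 is therefore estimated at 65%, ranging from 25% to 95%.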

Compound 4, largest response reached (reported as percent of maximum), in percent of the reference or control that the assay uses: 84.5%
Beside the measured number, compound 4's estimate is 19.5 percentage points below it, within the range that was stated.
By their numbers in this assay, from the lowest: compounds 1 and 2 (each within the scatter of the next); then compounds 4 and 3 (each within the scatter of the next).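

In this assay, among these compounds, the step of a number 68.1 percentage points higher from compound 2 to compound 4 (beyond the scatter) shows that bringing a carboxy group in on this oxygen gives a large gain with isopropyl on the chain carbon too, where it had previously been seen only with cyclopentyl. The gain is also not confined to 4-carboxy-2-methylphenyl, as 3-carboxy-4-fluorophenyl produces it as well. No measurement at hand explains this gain. The compounds shown leave open what the fluorine adds apart from the carboxy group, and whether a tetrazole or a primary amide in place of the carboxylic acid would keep the response.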